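The source may hold more compounds than are shown below. What is called first, only, known or untested is meant among the compounds shown, and "the series" means these compounds.

Measured in a toxicity assay on L02 cells (Homo sapiens) for cytotoxicity, read by MTT assay, with a stated time of 72 h; on this read-out higher numbers stand for weaker inhibition and lower numbers for stronger inhibition:
- compound 1 `CN(C)CCCCCn1c2c(c3ccccc31)C(=O)c1c[n+]([O-])c3ccccc3c1C2=O`: 240 nM
- compound 2 `CCCCN1CCN(CCCCn2c3c(c4ccccc42)C(=O)c2c[n+]([O-])c4ccccc4c2C3=O)CC1`: 5690 nM
- compound 3 `O=C1c2c[n+]([O-])c3ccccc3c2C(=O)c2c1c1ccccc1n2Cc1cn([C@H]2C[C@H](O)[C@@H](CO)O2)nn1`: 280 nM

Compound 2 has the highest of these three numbers, well clear of the other two. Compound 4 `CN1CCN(CCCCCCn2c3c(c4ccccc42)C(=O)c2c[n+]([O-])c4ccccc4c2C3=O)CC1` differs from it as follows: 2-(4-methylpiperazin-1-yl)ethyl in place of 4-butylpiperazin-1-yl on a saturated chain carbon, four bonds along the chain from an aromatic nitrogen. In words, 2-(4-methylpiperazin-1-yl)ethyl stands in place of 4-butylpiperazin-1-yl on a saturated chain carbon, four bonds along the chain from an aromatic nitrogen.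

Among the compounds with values here, no measured step covers this exact exchange. The nearest is a 24-fold higher number from compound 1 to compound 2 (1.37 log units; beyond the scatter), a large step that brought in 4-butylpiperazin-1-yl at that same place. With that group leaving, a moderate move to a lower number is expected in this assay, though with little certainty. The expected change is a 3.8-fold lower number from compound 2 to compound 4 (0.58 log units; beyond the scatter). For compound 4 the estimate is 1500 nM, with an expected range of 300 nM to 6000 nM.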

Compound 4, half-maximal inhibitory concentration: 3800 nM
Compound 4: the middle estimate sits 2.5-fold (0.40 log units) below what was measured, and the stated range covers the measured number.
By their numbers in this assay, from the lowest: compounds 1 and 3 (each within the scatter of the next); then compounds 4 and 2 (each within the scatter of the next).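

In this assay the longer methylpiperazine chain brings a 1.5-fold lower number from compound 2 to compound 4 (0.18 log units; within the scatter) and so cannot be told apart from the butylpiperazine one. Replacing dimethylamino with (4-methylpiperazin-1-yl)methyl brings a 16-fold higher number from compound 1 to compound 4 (1.20 log units; beyond the scatter), which shows that the large gap from the dimethylamino compound is not confined to the butylpiperazine group. Nothing available explains this gap. Still open, from the compounds shown here alone, is how a morpholine or a piperidine would read at this place in this assay, and whether a piperazine with no group on its far nitrogen would stay with compound 2 and compound 4.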